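Iodo swapped for an aminomethyl group on the shared core

The source may hold more compounds than are shown below. What is called first, only, known or untested is meant among the compounds shown, and "the series" means these compounds.

- compound 1 `CCc1cc(C2CCCCC2)n(O)c(=O)c1` gives 4.53 10^-6 cm/s in an ADME assay for permeability, using PAMPA, with a stated time of 10 h; a higher number here means that the compound crosses the layer faster, a lower number that the compound crosses the layer more slowly
- compound 2 `Cc1cc(C2CCCCC2)n(O)c(=O)c1I` gives 7.65 10^-6 cm/s in this assay

Compound 2 stands within the scatter of compound 1 on these two values, so the pair sets no order and offers a single level as the starting point. For the measured compounds named here, the two compounds do not differ in just one place, and the series so far holds no measured single-change step to serve as a guide.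

The next compound is compound 3 `Cc1cc(C2CCCCC2)n(O)c(=O)c1CNC1CCCC1`, not yet measured. Its difference from compound 2 is (cyclopentylamino)methyl in place of iodo on an aromatic carbon, with (cyclopentylamino)methyl in place of iodo on an aromatic carbon, para to a group of 6 heavy atoms. Going by the values given here, this is a large change in counted terms, and a fall beyond the scatter is expected in this assay, though this is a judgement from the structures alone, with no measured precedent. The expected move is a 5.1-fold lower number from compound 2 to compound 3 (0.71 log units; beyond the scatter) as an estimate. The estimated value for compound 3 is 1.5 10^-6 cm/s, with an expected range from 0.3 10^-6 cm/s to 6 10^-6 cm/s in this estimate.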

Compound 3, apparent permeability: 3.89 10^-6 cm/s
For compound 3 the middle estimate is 2.6-fold (0.41 log units) below the measured one; measured number inside the range.
By their numbers in this assay, from the lowest: compounds 3, 1 and 2 (each within the scatter of the next).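

For the compounds shown here, this is the only single-place step so far, and it gives a first reading for this aromatic carbon, para to a group of 6 heavy atoms: in this assay the exchange of iodo for (cyclopentylamino)methyl gives a 2.0-fold lower number from compound 2 to compound 3 (0.29 log units; within the scatter), so compound 3 and compound 2 cannot be told apart on this read-out. The change is large in counted terms, with a single iodine atom leaving and 7 heavy atoms entering, including one five-membered non-aromatic ring, 1 hydrogen-bond donor and 1 hydrogen-bond acceptor, yet that whole exchange produces no step beyond the scatter at this position. No measurement bears on why the step is this small, so the result stands as an observation without an explanation.

The ring and the nitrogen enter together in this one step, so the compounds shown do not separate their contributions; an open-chain amine such as a diethylaminomethyl group, or a cyclopentylmethyl group with no nitrogen, would bear on that. Going by these compounds, how far the finding extends at this carbon also remains open, for example to a carboxylic acid or a longer chain.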